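One More Aryl Swap at the Assay Limit

The source may report more compounds than this note shows. Statements on the series, on what has been measured and on what is new or still open speak of the compounds shown alone.

In a functional assay on OVCAR-3 cells (Homo sapiens) for antiproliferative activity, read by spectrophotometry, with a stated time of 2 days (on this read-out higher numbers stand for weaker inhibition of growth and lower numbers for stronger inhibition of growth), compound 3 (`COc1ccc(C(F)(F)F)cc1Nc1ncc(C(F)(F)F)c(N2Cc3cccc(N(C)S(C)(=O)=O)c3C2)n1`) gives > 30000 nM as a limit of the assay, not a number. Compound 1 (`COc1ccc(Nc2ncc(C(F)(F)F)c(N3Cc4cccc(N(C)S(C)(=O)=O)c4C3)n2)cc1C(F)(F)F`) gives > 30000 nM as a limit too. Compound 2 (`Cc1ccc(Nc2ncc(C(F)(F)F)c(N3Cc4cccc(N(C)S(C)(=O)=O)c4C3)n2)cc1C`) also gives > 30000 nM as a limit. Compound 3 therefore has no rank of its own (the limit of > 30000 nM in this assay, at which 3 of the 3 values shown sit).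

Compound 4 (`Cc1ccc(Nc2ncc(C(F)(F)F)c(N3Cc4cccc(N(C)S(C)(=O)=O)c4C3)n2)c(Cl)c1`) carries 2-chloro-4-methylphenyl in place of 2-methoxy-5-(trifluoromethyl)phenyl on a nitrogen on an aromatic ring. Three swaps at this same place bear on the new one (a step that the two limits leave unreadable from compound 1 to compound 2 and a step that the two limits leave unreadable from compound 1 to compound 3 and a step that the two limits leave unreadable from compound 2 to compound 3), and none of them has a readable size. All three aryl groups tried so far end at the limit, so no step beyond the scatter is expected, in either direction. The expected outcome is a number no higher from compound 3 to compound 4 (the limit leaves the size open) with compound 4 most likely reported as a limit again. For compound 4 the estimate is 30000 nM with an expected range from 8000 nM to 60000 nM if a number is reported at all.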

Compound 4, concentration for 50% growth inhibition: > 30000 nM
Compound 4 was reported as a limit; the forecaster's own chance of this, stated with the estimate: 70%; the middle value lies on the limit itself.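

Compound 4 ends at the same assay limit as compound 1, compound 2 and compound 3, so its steps to all three cannot be read: the limit of > 30000 nM in this assay, at which 4 of the 4 values shown sit.

The compounds shown leave open whether any aryl group at this place gives a readable value, and how much each swap changes growth inhibition.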